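The compounds below may be only part of what the source reports. "The series", "measured", "known", "first", "only" and "open" are said of these compounds alone.

Compound 1 `Brc1ccc(-n2cc(COc3ccc4c(c3)CCC4)nn2)cc1`: "not determined" (no result reported)
Compound 2 `COc1cccc(-n2cc(COc3ccc4c(c3)CCC4)nn2)c1`: 25.8%
Compound 3 `Clc1ccc(-n2cc(COc3ccc4c(c3)CCC4)nn2)cc1`: "not determined" (no result reported)

All three share the same core and differ only in the group on the outer aromatic ring. In an ADME assay on HEK293 cells (Homo sapiens) for inhibition, read by MTT assay, with a stated time of 48 h, tested at 25 uM (on this read-out lower numbers stand for less inhibition and higher numbers for more inhibition at the one concentration tested (going by the name of the read-out)), compound 2 gives 25.8%, while compound 3 and compound 1 have no number at all, so compound 3 stands nowhere on this scale yet. Compound 4 `COc1ccc(-n2cc(COc3ccc4c(c3)CCC4)nn2)cc1` is reached from compound 3 by one change: methoxy in place of chloro on an aromatic carbon. For the measured compounds named here, with no measured value for compound 3, no step in this assay can be stated for this change, and there is nothing to set its size or direction. Going by the values given here, the only anchor is compound 2, which carries the same methoxy group on the same outer ring. Compound 4 is therefore expected to give about 25%, within 5% to 50%, due to compound 2 giving 25.8%.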

Compound 4, a percentage reported as inhibition, at one concentration (the size of the read-out at that concentration, not a potency): 21.1%
Compound 4: middle estimate off by 3.9 percentage points, on the high side; the measured number falls inside the stated range.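

In this assay, moving from 3-methoxyphenyl to 4-methoxyphenyl on the aromatic nitrogen gives a number 4.7 percentage points lower from compound 2 to compound 4 (within the scatter) and so leaves the two methoxy placements indistinguishable on this read-out. For the compounds shown here, this is the first readable comparison at this outer ring, and it concerns only where the methoxy group sits. The steps from compound 1 and compound 3 cannot be read, as neither compound has a number, so methoxy and chloro remain uncompared.

As far as these compounds go, whether an amine or a carboxylic acid at this place would give a different number stays open. No further measurement bears on what lies behind this result.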